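Furan-3-yl in place of 1H-imidazol-4-yl

The source may hold more compounds than are shown below. What is called first, only, known or untested is meant among the compounds shown, and "the series" means these compounds.

In a functional assay on CCRF-CEM cells (Homo sapiens) for cytotoxicity, read by XTT assay, with a stated time of 3 days (a higher number here means a weaker inhibitor, a lower number a stronger inhibitor), compound 2 (`OC[C@H]1O[C@@H](n2cc(F)c3c(-c4c[nH]cn4)ncnc32)[C@H](O)[C@@H]1O`) gives 1800 nM and compound 1 (`OC[C@H]1O[C@@H](n2cc(F)c3c(-c4ccco4)ncnc32)[C@H](O)[C@@H]1O`) gives 1400 nM on the same scale, so the two values lie within the scatter of each other. Compound 3 (`OC[C@H]1O[C@@H](n2cc(F)c3c(-c4ccoc4)ncnc32)[C@H](O)[C@@H]1O`) has furan-3-yl in place of 1H-imidazol-4-yl on an aromatic carbon. For the measured compounds named here, replacing furan-2-yl with 1H-imidazol-4-yl gave a 1.3-fold higher number from compound 1 to compound 2 (0.11 log units; within the scatter) and this is the only measured step that bears on the change. Going by the values given here, no measured compound yet carries furan-3-yl. On that single step, no shift beyond the scatter is expected in this assay and no direction is favoured. The expected move is a 1.1-fold lower number from compound 2 to compound 3 (0.05 log units; within the scatter) and it remains an estimate. For compound 3 the estimated value is 1600 nM with an expected range of 650 nM to 4000 nM for that compound.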

Compound 3, half-maximal inhibitory concentration: 1000 nM
The estimate for compound 3 lay 1.6-fold (0.20 log units) above the measured number, and the stated range covers the measured number.
By their numbers in this assay, from the lowest: compounds 3, 1 and 2 (each within the scatter of the next).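

Notes on the group on the aromatic carbon opposite the ring nitrogen, in this assay: furan-3-yl in place of 1H-imidazol-4-yl gives a 1.8-fold lower number from compound 2 to compound 3 (0.26 log units; within the scatter), and furan-3-yl in place of furan-2-yl gives a 1.4-fold lower number from compound 1 to compound 3 (0.15 log units; within the scatter). Both the change of furan attachment point and the loss of the hydrogen-bond donor carried by 1H-imidazol-4-yl therefore leave the number within the scatter, so compounds 1, 2 and 3 cannot be separated at this position by this read-out. No supporting data are available to explain this flat result.

As far as these compounds go, all three groups are five-membered aromatic rings, so it remains open whether a non-aromatic group at this place, such as a primary amine, a carboxylic acid or a longer alkyl chain, would move the number beyond the scatter. From the compounds shown here alone, a six-membered ring such as phenyl or pyridyl is equally open.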